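The source may hold more compounds than are shown below. What is called first, only, known or untested is meant among the compounds shown, and "the series" means these compounds.

Measured in a physicochemical assay for solubility, read by chemiluminescence (on this read-out higher numbers stand for higher solubility and lower numbers for lower solubility), so far
compound 1 `CN1CCC(C(=O)N(CC(=O)Nc2cc(F)cc(F)c2)C2CCCCC2)CC1` gives 140 ug/mL
compound 2 `Cn1ccc(C(=O)N(CC(=O)Nc2cc(F)cc(F)c2)C2CCCCC2)n1` gives 163 ug/mL
compound 3 `O=C(CN(CC1CC1)C(=O)c1ccc(-c2ccccn2)cc1)Nc1cc(F)cc(F)c1` gives 25 ug/mL

Compound 3 is the lowest of the three numbers, and its gaps to compound 1 and compound 2 lie beyond the scatter. Compound 4 `CCC(COC)N(CC(=O)Nc1cc(F)cc(F)c1)C(=O)c1ccc(-c2ccccn2)cc1` carries 1-(methoxymethyl)propyl in place of cyclopropylmethyl on an amide-type nitrogen, counted as 1-(methoxymethyl)propyl in place of cyclopropylmethyl on an amide-type nitrogen in full. Among the measured compounds shown here, no measured step changes that group. For the measured compounds named here, the one measured step of a 1.2-fold higher number from compound 1 to compound 2 (0.07 log units; within the scatter) lies within the scatter and sits on a carbonyl carbon, so it gives no size for this change. No direction is therefore favoured in this assay and the estimated step of a 1.1-fold higher number from compound 3 to compound 4 (0.05 log units; within the scatter) is expected to stay within the scatter. Compound 4 is estimated at 28 ug/mL with an expected range of 12 ug/mL to 65 ug/mL around that figure.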

Compound 4, solubility: 24 ug/mL
Compound 4: the middle estimate sits 1.2-fold (0.07 log units) above what was measured, and the stated range covers the measured number.
By their numbers in this assay, from the lowest: compounds 4 and 3 (each within the scatter of the next); then compounds 1 and 2 (each within the scatter of the next).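

In this assay, among the compounds shown here, the exchange of cyclopropylmethyl for 1-(methoxymethyl)propyl on an amide-type nitrogen gives a 1.0-fold lower number from compound 3 to compound 4 (0.02 log units; within the scatter) as the first measured step at this position. A group with 6 heavy atoms, no ring and 1 hydrogen-bond acceptor thus stands in for one with 4 heavy atoms and a three-membered ring, with the step staying within the scatter. No evidence available bears on this result.

On these data alone, whether an amine or a carboxylic acid on this nitrogen substituent would give a step beyond the scatter stays open. Also open, as far as these compounds go, is whether the same exchange reads alike with 1-methylpiperidin-4-yl or 1-methyl-1H-pyrazol-3-yl on the carbonyl carbon.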